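The compounds below may be only part of what the source reports. "The series", "measured", "known", "first", "only" and "open" are said of these compounds alone.

In a functional assay on HeLa cells (Homo sapiens) for antiproliferative activity, read by MTT assay, with a stated time of 72 h (on this read-out lower numbers stand for stronger inhibition and higher numbers for weaker inhibition), compound 1 (`C=CC(=O)Nc1cccc(Oc2nc(Nc3cccc(OC)c3)nc3c2CSCC3)c1`) gives 28900 nM while compound 2 (`CCC/C=C/C(=O)Nc1cccc(Oc2nc(Nc3cccc(OC)c3)nc3c2CSCC3)c1`) gives 33800 nM and compound 3 (`COc1cccc(Nc2nc3c(c(Oc4cccc(NC(=O)C=C(C)C)c4)n2)CSCC3)c1`) gives 19100 nM on the same read-out. These three numbers lie within the scatter of one another, so compound 3 stands level with the other two. Compound 4 (`COc1cccc(Nc2nc3c(c(Oc4cccc(NC(=O)/C=C/C(C)C)c4)n2)CSCC3)c1`) differs from compound 3 by a single change (3-methylbut-1-en-1-yl in place of 2-methylprop-1-en-1-yl on a carbonyl carbon), 3-methylbut-1-en-1-yl in place of 2-methylprop-1-en-1-yl on a carbonyl carbon. Three measured swaps at that place bear on it: the steps of a 1.2-fold higher number from compound 1 to compound 2 (0.07 log units; within the scatter) and a 1.5-fold lower number from compound 1 to compound 3 (0.18 log units; within the scatter) and a 1.8-fold lower number from compound 2 to compound 3 (0.25 log units; within the scatter) all stay within the scatter. No step beyond the scatter, in either direction, is therefore expected in this assay for this swap. The expected step is a 1.3-fold higher number from compound 3 to compound 4 (0.12 log units; within the scatter) and it is estimated to remain within the scatter. Compound 4 is estimated at 25000 nM with an expected range from 13000 nM to 45000 nM on this read-out.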

Compound 4, half-maximal inhibitory concentration: > 50000 nM
Compound 4: only a limit was reported; the forecaster's own chance of this, stated with the estimate: 8%; middle value at least 2.0-fold (0.30 log units) away from the limit.
By their numbers in this assay, from the lowest: compounds 3, 1 and 2 (each within the scatter of the next). At a limit, above all of these: compound 4.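

Compound 4 is held only as a limit in this assay: the limit of > 50000 nM in this assay, at which 1 of the 4 values shown sits. Among the compounds shown here, the step of an at least 2.6-fold higher number from compound 3 to compound 4 (0.41 log units; beyond the scatter) is the first beyond the scatter at this place on a carbonyl carbon, where the swaps among the earlier compounds had all stayed within it. The steps of an at least 1.4-fold higher number from compound 2 to compound 4 (0.17 log units; that floor lies within the scatter) and an at least 1.7-fold higher number from compound 1 to compound 4 (0.23 log units; that floor lies within the scatter) have floors within the scatter, so these two alone do not set compound 4 apart from compound 2 or compound 1. From the compounds shown here alone, how far the true value of compound 4 lies past its limit stays open, as does the effect of an amine or a carboxylic acid at the end of this chain.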